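The compounds below may be only part of what the source reports. "The series", "measured", "known", "first", "only" and "open" are said of these compounds alone.

Three members of this series have been tested in a functional assay on HCT-116 cells (Homo sapiens) for antiproliferative activity, read by MTT assay, with a stated time of 48 h; a higher number here means a weaker inhibitor, a lower number a stronger inhibitor. Compound 1 `COc1cc(-c2nnc(SCC(=O)c3ccccc3)n2N)cc(OC)c1OC` gives 53000 nM in this assay. Compound 2 `COc1cc(-c2nnc(SCC(=O)c3ccc(Br)cc3)n2N)cc(OC)c1OC` gives 9230 nM, a change read as a 5.7-fold lower number from compound 1 to compound 2 (0.76 log units; beyond the scatter). Compound 3 `COc1cc(-c2nnc(SCC(=O)NCc3ccc(Cl)cc3)n2N)cc(OC)c1OC` reaches only the limit of this assay, (the limit of > 100000 nM in this assay, at which 1 of the 3 values shown sits), so its value of > 100000 nM is a limit and not a number. The steps leading to it read an at least 10-fold higher number from compound 2 to compound 3 (1.03 log units; beyond the scatter) and an at least 1.8-fold higher number from compound 1 to compound 3 (0.27 log units; that floor lies within the scatter).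

Compound 4 `COc1cc(-c2nnc(SCC(=O)NCc3ccc(C)cc3)n2N)cc(OC)c1OC` differs from compound 3 by methyl in place of chloro on an aromatic carbon. For the measured compounds named here, no measured step repeats this change: the only one that alters a ring substituent, a 5.7-fold lower number from compound 1 to compound 2 (0.76 log units; beyond the scatter), puts bromo in place of hydrogen, and the two others exchange the whole group on the carbonyl carbon. Since compound 3 already stands at the limit, only a fall could be registered, and nothing shown points to one. Compound 4 is therefore expected near 130000 nM, within 40000 nM to 400000 nM, an expected step that the limit leaves unreadable from compound 3 to compound 4, with a limit the most likely outcome.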

Compound 4, half-maximal inhibitory concentration: > 100000 nM
Compound 4 ended at the assay's limit; the forecaster's own chance of this, stated with the estimate: 70%; the middle value is on the limit's open side.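

In this assay, the (4-methylbenzyl)amino group behaves like the (4-chlorobenzyl)amino group as far as can be told: the step between compound 3 and compound 4 cannot be read, since both values are limits. Exchanging the 4-bromophenyl group on the carbonyl carbon for this second benzylamino group again gives a large step, an at least 10-fold higher number from compound 2 to compound 4 (1.03 log units; beyond the scatter), while the other step, an at least 1.8-fold higher number from compound 1 to compound 4 (0.27 log units; that floor lies within the scatter), has a floor within the scatter and does not separate the two compounds. Chloro and methyl at this place, para to a large group, thus both leave the compound at the limit: the limit of > 100000 nM in this assay, at which 2 of the 4 values shown sit.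

The compounds shown leave open whether any substituent at this place, such as a methoxy group or an amine, would bring a benzylamino compound into the readable range. They also leave open how far below the limit, if at all, either compound 3 or compound 4 would lie under a wider concentration range.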